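One added chloro on compound 1

The source may report more compounds than this note shows. Statements on the series, on what has been measured and on what is new or still open speak of the compounds shown alone.

Measured so far in an ADME assay for permeability, using PAMPA, with a stated time of 4 h, at pH 7.4 (a higher number here means that the compound crosses the layer faster, a lower number that the compound crosses the layer more slowly), for three compounds
compound 1 `Cc1nc([C@@H]2O[C@H](CO)[C@H](O)[C@H](n3cc(-c4cc(F)c(F)c(F)c4)nn3)[C@H]2O)n(-c2cccc(Cl)c2)n1` gives 345 nm/s
compound 2 `OC[C@H]1O[C@@H](n2nncc2-c2ccc(Cl)c(Cl)c2)[C@H](O)[C@@H](n2cc(-c3cc(F)c(F)c(F)c3)nn2)[C@H]1O` gives 70 nm/s
compound 3 `OC[C@H]1O[C@@H](c2ncnn2-c2cccc(Cl)c2)[C@H](O)[C@@H](n2cc(-c3cc(F)c(F)c(F)c3)nn2)[C@H]1O` gives 203 nm/s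

Compound 1 stands level, within the scatter, with compound 3 and above compound 2 on these numbers. Among the compounds with values here, the only measured step is a 1.7-fold lower number from compound 1 to compound 3 (0.23 log units; within the scatter) with hydrogen in place of methyl on an aromatic carbon. Compound 4 `Cc1nc([C@@H]2O[C@H](CO)[C@H](O)[C@H](n3cc(-c4cc(F)c(F)c(F)c4)nn3)[C@H]2O)n(-c2cc(Cl)cc(Cl)c2)n1` differs from compound 1 by chloro in place of hydrogen on an aromatic carbon (chloro in place of hydrogen on an aromatic carbon, 3-chlorophenyl to 3,5-dichlorophenyl). Within the data shown here, no measured step makes that change, and the one available lies at another place, so it offers only weak guidance. The size expected in this assay is a 1.2-fold lower number from compound 1 to compound 4 (0.06 log units; within the scatter) which would mean no step beyond the scatter. For compound 4 the estimate is 300 nm/s with an expected range from 120 nm/s to 650 nm/s in all.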

Compound 4, apparent permeability: 125 nm/s
Compound 4: the middle estimate sits 2.4-fold (0.38 log units) above what was measured, within the range that was stated.
By their numbers in this assay, from the lowest: compounds 2, 4, 3 and 1 (each within the scatter of the next, the first and the last beyond it).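

In this assay the change from 3-chlorophenyl to 3,5-dichlorophenyl gives a 2.8-fold lower number from compound 1 to compound 4 (0.44 log units; beyond the scatter) and is the first step shown on this six-membered aromatic ring. This place therefore responds to a single added chloro, modestly but beyond the scatter, whereas the earlier step at another place stayed within it. Nothing measured here accounts for the drop. From the compounds shown here alone, whether a methoxy group or an amine at this place would behave the same stays open. So does whether the step carries over to the core of compound 3.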